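This account rests on a few compounds, and the source may have more. Where it says the series, first, only, none or still open, it means among the compounds named here.

In an in vitro functional assay on RBL cells for antagonist activity at C-C chemokine receptor type 8 (Homo sapiens), read by FLIPR and calcium flux (on this read-out higher numbers stand for weaker inhibition and lower numbers for stronger inhibition), compound 1, `O=C1OC(c2ccnc3ccccc23)CN1C1CCN(Cc2cc3ccccc3[nH]2)CC1`, gives 1000 nM. Compound 2, `CCCCCCN1CCC(N2CC(c3ccnc4ccc(OC)cc34)OC2=O)CC1`, gives 501 nM in this assay . Among the measured compounds shown here, of the two numbers measured so far, that of compound 2 is the smaller, but the gap to compound 1 lies within the usual scatter of repeated measurements, so the two compounds cannot be told apart on these data.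

Compound 3, `COc1ccc2nccc(C3CN(C4CCN(S(=O)(=O)c5ccc(Cl)c(Cl)c5)CC4)C(=O)O3)c2c1`, has not yet been measured. It differs from compound 2 in one place: (3,4-dichlorophenyl)sulfonyl in place of hexyl on an amine nitrogen in a ring. For the measured compounds named here, no pair of measured compounds shows a change of this kind, so there is nothing in the data to anchor the size of the step. The number for compound 3 is therefore estimated with wide bounds, and the step from compound 2 is expected to be a 4.0-fold higher number from compound 2 to compound 3 (0.60 log units; beyond the scatter), toward weaker inhibition. Compound 3 is estimated to give 2000 nM, with a range from 500 nM to 8000 nM.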

Compound 3, half-maximal inhibitory concentration: < 50200 nM
Compound 3: only a limit was reported (the forecaster's own chance of this, stated with the estimate: 15%); the middle value does not contradict the limit.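

In this assay compound 3 gives only a limit, < 50200 nM, and not a number, so the step from compound 2 to compound 3 cannot be read. From the compounds shown here alone, how far (3,4-dichlorophenyl)sulfonyl in place of hexyl shifts inhibition, and in which direction, stays open.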